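Solubility at the Limit: From Phenylethyl to Fluorobenzyl

The source may report more compounds than this note shows. Statements on the series, on what has been measured and on what is new or still open speak of the compounds shown alone.

Compound 1 `CNC(=O)c1cc(C(=O)NC2CC2)cn([C@H](C)c2ccccc2)c1=O` carries a 1-phenylethyl group on the aromatic nitrogen of the shared core. In a physicochemical assay for solubility (on this read-out lower numbers stand for lower solubility and higher numbers for higher solubility), compound 1 gives >= 168 ug/mL, which is a limit of the assay and not a number. The two other measured members of the series also stop at limits. Compound 2 `CNC(=O)c1cc(C(=O)NC2CCOCC2)cn(Cc2ccccc2)c1=O` gives >= 174 ug/mL in this assay, a limit. Compound 3 `CNC(=O)c1cc(C(=O)NCCO)cn(Cc2ccccc2)c1=O` gives >= 140 ug/mL in this assay, also a limit. For the measured compounds named here, the single measured step, a step that the two limits leave unreadable from compound 2 to compound 3, cannot be sized, so no measured step bears in size on the change from compound 1 to compound 4; what the three results share is that all sit at a limit: the limit of >= 140 ug/mL in this assay, at which 1 of the 3 values shown sits, the limit of >= 168 ug/mL in this assay, at which 1 of the 3 values shown sits, and (the limit of >= 174 ug/mL in this assay, at which 1 of the 3 values shown sits).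

Compound 4 `CNC(=O)c1cc(C(=O)NC2CC2)cn(Cc2ccccc2F)c1=O` differs from compound 1 in one place: 2-fluorobenzyl in place of 1-phenylethyl on an aromatic nitrogen. Because compound 1 sits at >= 168 ug/mL, a limit, compound 4 is expected to sit at a limit as well, with no readable step. The estimate for compound 4 in this assay is 170 ug/mL, ranging from 120 ug/mL to 230 ug/mL. The expected step that the limit leaves unreadable from compound 1 to compound 4 is therefore none beyond the scatter, and the assay is likely to return only a limit again.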

Compound 4, solubility: >= 145 ug/mL
Compound 4 ended at the assay's limit; the forecaster's own chance of this, stated with the estimate: 85%; the middle value does not contradict the limit.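

In this assay compound 4 gives >= 145 ug/mL, which is a limit of the assay and not a number. Compound 1 also stands at a limit, and the step between compound 1 and compound 4 cannot be read. The compounds shown leave open how far 2-fluorobenzyl and 1-phenylethyl on the aromatic nitrogen differ on this read-out, if they differ at all.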